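Swapping dipropylamino for (tert-butyl)amino on the chain

The compounds below may be only part of what the source reports. "The series", "measured", "known", "first", "only" and "open" are said of these compounds alone.

In a functional assay (aorta) with Rattus norvegicus as the target (on this read-out higher numbers stand for weaker inhibition and lower numbers for stronger inhibition), compound 3 (`CCCN(CCC)CCCOc1ccc(S(=O)(=O)c2c(C(C)C)cn3ccccc23)cc1`) gives 102 nM. Compound 2 (`CC(C)(C)NCCCOc1ccc(S(=O)(=O)c2c(C3CC3)cn3ccccc23)cc1`) gives 66.5 nM, within the scatter of compound 3, while compound 1 (`COc1ccc(CNCCCOc2ccc(S(=O)(=O)c3c(C(C)C)cn4ccccc34)cc2)cc1OC`) gives 13 nM. The next change, to compound 4 (`CC(C)c1cn2ccccc2c1S(=O)(=O)c1ccc(OCCCNC(C)(C)C)cc1`), is (tert-butyl)amino in place of dipropylamino on a saturated chain carbon, three bonds along the chain from an oxygen on an aromatic ring. Among the compounds with values here, the one measured step at this place is a 7.8-fold higher number from compound 1 to compound 3 (0.89 log units; beyond the scatter), so the amine group can move the number. Compound 2 carries the same (tert-butyl)amino on a differently substituted core and gives 66.5 nM, which argues against a large shift. Hence a small fall, or none beyond the scatter, is expected, and the estimated step is a 1.7-fold lower number from compound 3 to compound 4 (0.23 log units; within the scatter). Compound 4 is estimated at 60 nM, with an expected range of 20 nM to 170 nM.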

Compound 4, half-maximal inhibitory concentration: 41.8 nM
Estimate against measurement, compound 4: 1.4-fold (0.16 log units) above, and the stated range covers the measured number.
By their numbers in this assay, from the lowest: compound 1; then compounds 4, 2 and 3 (each within the scatter of the next, the first and the last beyond it).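

In this assay, (tert-butyl)amino in place of dipropylamino gives a 2.4-fold lower number from compound 3 to compound 4 (0.39 log units; beyond the scatter), so this swap on an unchanged core moves the number beyond the scatter. On the amine nitrogen, tert-butyl in place of 3,4-dimethoxybenzyl gives a 3.2-fold higher number from compound 1 to compound 4 (0.51 log units; beyond the scatter), whereas isopropyl in place of cyclopropyl on an aromatic carbon gives a 1.6-fold lower number from compound 2 to compound 4 (0.20 log units; within the scatter), which does not separate that pair. Nothing measured here accounts for these steps.

Still open, on these data alone, is whether plain benzyl or 4-methoxybenzyl on the amine nitrogen would keep the number seen with 3,4-dimethoxybenzyl. A longer chain also remains to be read.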